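Ether Swaps on the Shared Core

A few compounds are considered here, and "the series" means these few. Any claim that something is new, unique, unknown or untested is made for them only; others in the source may bear on it.

Compound 1 `COc1cc(C(=O)Nc2cc(OC(F)(F)F)ccc2-n2cncn2)ccc1OC(C)C`: 0.065
Compound 2 `COc1cc(C(=O)Nc2cc(OC(F)(F)F)ccc2-n2cncn2)ccc1OC1CC1`: 0.052

Both compounds share one core and were measured in an ADME assay on a cell-free system (plasma, Rattus norvegicus) for protein binding, read by LC-MS, using equilibrium dialysis, with a stated time of 4 h; on this read-out higher numbers stand for a larger free fraction and lower numbers for a smaller free fraction. Within the data shown here, compound 2 gives the smaller of the two numbers, yet the single measured step, a 1.3-fold lower number from compound 1 to compound 2 (0.10 log units; within the scatter), lies within the scatter, so the two compounds cannot be told apart on this read-out.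

Compound 3 `CCOc1ccc(C(=O)Nc2cc(OC(F)(F)F)ccc2-n2cncn2)cc1OC` has not yet been measured. It differs from compound 2 by ethyl in place of cyclopropyl on an oxygen on an aromatic ring. Among the measured compounds shown here, the only step that bears on this change is the one from isopropyl to cyclopropyl at the same oxygen, a 1.3-fold lower number from compound 1 to compound 2 (0.10 log units; within the scatter), which was within the scatter. A move to ethyl at that oxygen is a small change of a similar kind, and nothing in the measured pair points to a shift beyond the scatter in either direction.

Compound 3 is therefore expected to give about 0.065 in this assay, with a likely range from 0.035 to 0.12. The expected step is a 1.3-fold higher number from compound 2 to compound 3 (0.10 log units; within the scatter), which is expected to stay within the scatter.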

Compound 3, unbound fraction: 0.072
Estimate against measurement, compound 3: 1.1-fold (0.04 log units) below, and the stated range covers the measured number.
By their numbers in this assay, from the lowest: compounds 2, 1 and 3 (each within the scatter of the next).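

At this oxygen on an aromatic ring, the result adds an open chain to the comparison: in this assay, ethyl in place of cyclopropyl gives a 1.4-fold higher number from compound 2 to compound 3 (0.14 log units; within the scatter), so removing the three-membered ring produces no readable change in the unbound fraction. Hydrogen in place of one methyl of the isopropyl group, which turns it into ethyl, gives a 1.1-fold higher number from compound 1 to compound 3 (0.04 log units; within the scatter), and this step cannot be told from repeat-measurement noise either. All three ether groups therefore read alike on this core, although nothing measured here offers a reason for that.

Going by these compounds, what remains open is how far this tolerance extends at the same oxygen, since these three small carbon groups sample only a narrow range of possible replacements. A longer chain, or a chain ending in an amine or a carboxylic acid, might move the unbound fraction beyond the scatter or might leave it where these compounds sit, and the compounds shown cannot settle which.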